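A few compounds are considered here, and "the series" means these few. Any claim that something is new, unique, unknown or untested is made for them only; others in the source may bear on it.

Compound 1, with the structure `COc1nc(-c2ccccc2)cc(-c2ccc(F)cc2)c1C#N`, gives 25 nM in an assay on isolated protein for inhibition of sulfide:quinone oxidoreductase, mitochondrial (Homo sapiens) (on this read-out lower numbers stand for stronger inhibition and higher numbers for weaker inhibition), the lowest of the two numbers in hand. Among the measured compounds shown here, its nearest neighbour is compound 2, `COc1ccccc1-c1cc(-c2ccc(F)cc2)c(C#N)c(OC)n1`, which gives 75 nM in this assay; the step of a 3.0-fold higher number from compound 1 to compound 2 (0.48 log units; beyond the scatter) is the only measured change so far, and it came from a methoxy in place of hydrogen on an aromatic carbon.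

Compound 3, `COCCOc1nc(-c2ccccc2)cc(-c2ccc(F)cc2)c1C#N`, differs from compound 1 in another way: methoxymethyl in place of hydrogen on a saturated chain carbon bound to an oxygen on an aromatic ring. The methoxy group on the shared core is kept and lengthened into a 2-methoxyethoxy chain, so the change lies on the chain rather than on an aromatic carbon. For the measured compounds named here, the step from compound 1 to compound 2 therefore bears on it only loosely: it shows that adding a methoxy elsewhere weakened inhibition modestly, but no measured step touches this chain. A small step in this assay is expected, if any, leaning toward a slightly higher number. The estimate for compound 3 is 40 nM, between 15 nM and 110 nM, a step of a 1.6-fold higher number from compound 1 to compound 3 (0.20 log units; within the scatter) from compound 1.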

Compound 3, half-maximal inhibitory concentration: 123 nM
Compound 3: middle estimate off by 3.1-fold (0.49 log units), on the low side, and the stated range ends below it.
By their numbers in this assay, from the lowest: compound 1; then compounds 2 and 3 (each within the scatter of the next).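

Lengthening the methoxy group of compound 1 into a 2-methoxyethoxy chain is not a neutral change at this position: in this assay it gives a 4.9-fold higher number from compound 1 to compound 3 (0.69 log units; beyond the scatter). The saturated chain carbon bound to an oxygen on an aromatic ring therefore does not take the added methoxymethyl without a loss of inhibition. Until now the only measured change was on an aromatic carbon; this step shows that a change on the chain also leads to a higher number, so both changes to compound 1 shown here weaken inhibition, and nothing at hand explains this loss.

Going by these compounds, it remains open whether the loss follows from the greater length of the chain alone or from the oxygen within it, a question that a plain ethoxy or propoxy group on the same core could help to separate. Also open, on these data alone, is how a chain ending in an amine or a carboxylic acid would behave at this position, and whether any group here can reach a lower number than compound 1 does.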